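The source may hold more compounds than are shown below. What is called first, only, known or untested is meant among the compounds shown, and "the series" means these compounds.

Working notes on a series sharing one core, measured in an assay for inhibition of NADPH oxidase 1 (Homo sapiens), read by chemiluminescence; on this read-out higher numbers stand for weaker inhibition and lower numbers for stronger inhibition.

Compound 1 `CN1C(=S)N(C2CCCCC2)C(=O)/C1=C/c1cccc(O)c1O` gives in this assay 7390 nM. Compound 3 `CCc1ccc(N2C(=O)/C(=C/c3cccc(O)c3O)N(C)C2=S)cc1` differs from compound 1 by 4-ethylphenyl in place of cyclohexyl on an amide-type nitrogen in a ring; in this assay compound 3 gives 27900 nM, which makes a 3.8-fold higher number from compound 1 to compound 3 (0.58 log units; beyond the scatter). Compound 2 `CN1C(=S)N(C2CCCCC2)C(=O)/C1=C/c1ccc(N(C)C)cc1` gives in this assay 12300 nM. The difference between the core of compound 2 and the core of compound 1 is not broken down here. The values of compound 2 and compound 1 lie within the scatter of each other, so no order between them is claimed; compound 3 shows a higher number than compound 2, and that gap lies beyond the scatter.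

Compound 4 `CCc1ccc(N2C(=O)/C(=C/c3ccc(N(C)C)cc3)N(C)C2=S)cc1` has not yet been measured in this assay. It differs from compound 2 by 4-ethylphenyl in place of cyclohexyl on an amide-type nitrogen in a ring. The place of this change reads the same word for word as in the change from compound 1 to compound 3, so the same change is made on the core of compound 2; across the four compounds it occurs twice, once measured and once not.

Among the compounds with values here, for compound 4 the expected step from compound 2 is a 3.4-fold higher number from compound 2 to compound 4 (0.53 log units; beyond the scatter), set beside the measured step because a 3.8-fold higher number from compound 1 to compound 3 (0.58 log units; beyond the scatter) is the only precedent for this change, and it sits on a different core, so the expectation carries wide uncertainty. Compound 4 is expected to give in this assay about 42000 nM, with the estimate spanning from 15000 nM to 120000 nM.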

Compound 4, inhibition constant: 4390 nM
Compound 4: middle estimate off by 9.6-fold (0.98 log units), on the high side, and the stated range ends above it.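

On the core of compound 2, 4-ethylphenyl in place of cyclohexyl on an amide-type nitrogen in a ring gives in this assay a 2.8-fold lower number from compound 2 to compound 4 (0.45 log units; beyond the scatter), whereas the same change on the core of compound 1 moves the number the other way. In this series the change therefore does not carry from one core to the other, either in direction or in size: the same change on two cores in this assay, a 3.8-fold higher number (0.58 log units; beyond the scatter) from compound 1 to compound 3 and a 2.8-fold lower number (0.45 log units; beyond the scatter) from compound 2 to compound 4, 11-fold (1.02 log units) apart, beyond the scatter of two such steps.

Within the data shown here, this shows that a step measured on one core was no guide to the step on the other here, but it rests on only two pairs of compounds and gives no general rule for other cores, nor does it show which feature of the two cores goes with the reversal.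

The compounds shown leave open whether the reversal follows the whole of the part in which the two cores differ or only some piece of it, as just two versions of that part appear. They also leave open how a carboxylic acid, an amine or a longer chain on the phenyl ring in place of the ethyl group would behave on an amide-type nitrogen in a ring of either core.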